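Dihydropyridine diesters with a chlorophenyl thiazole: ethyl to cyclohexyl

The source may hold more compounds than are shown below. What is called first, only, known or untested is meant among the compounds shown, and "the series" means these compounds.

Measured so far:
- compound 1, `CCOC(=O)C1=C(C)NC(C)=C(C(=O)OCC)C1c1csc(-c2ccc(Cl)cc2)n1`: 3650 nM
- compound 2, `CC1=C(C(=O)OC(C)(C)C)C(c2csc(-c3ccc(Cl)cc3)n2)C(C(=O)OC(C)(C)C)=C(C)N1`: 21000 nM

Both compounds share one core and differ in their two ester groups. In an assay on isolated protein for antagonist activity at Voltage-dependent L-type calcium channel subunit alpha-1C (Cavia porcellus), with a stated time of 15 min (a lower number here means a stronger inhibitor, a higher number a weaker inhibitor), compound 1 gives 3650 nM, the lower of the two numbers. Compound 2 gives 21000 nM, a higher number, and the gap between the two lies beyond the usual scatter of this assay, so compound 1 is the stronger of the pair.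

Compound 3, `CCOC(=O)C1=C(C)NC(C)=C(C(=O)OC2CCCCC2)C1c1csc(-c2ccc(Cl)cc2)n1`, is not yet measured. It differs from compound 1 in one place: cyclohexyl in place of ethyl on an oxygen next to a carbonyl group. One ester thus carries a larger ring in place of the short chain while the other ester is unchanged. Because compound 2 gives 21000 nM with both esters enlarged, a loss is possible, but a single change is expected to stay within the scatter, with a 1.0-fold lower number from compound 1 to compound 3 (0.02 log units; within the scatter). Compound 3 is therefore estimated at 3500 nM, between 1200 nM and 11000 nM.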

Compound 3, half-maximal inhibitory concentration: 100000 nM
Compound 3: middle estimate off by 29-fold (1.46 log units), on the low side; measured number outside the range, above it.
By their numbers in this assay, from the lowest: compound 1; then compound 2; then compound 3.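

In this assay the change of one ester alone, with cyclohexyl in place of ethyl on an oxygen next to a carbonyl group, gives a 27-fold higher number from compound 1 to compound 3 (1.44 log units; beyond the scatter) and so counts as a large step. The earlier pair differed in both esters, so it could not show what a change at a single ester does; this step shows that one such change, with the other ester left as it is, is enough for a large loss of inhibition. Nothing in the data on hand explains why this loss occurs.

The compounds shown do not tell whether the loss follows from the ring itself or from the larger number of carbons. A straight hexyl chain at this ester would separate those two readings, and a smaller methyl ester would show whether shortening the ethyl group changes the number at all.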